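This account rests on a few compounds, and the source may have more. Where it says the series, first, only, none or still open, it means among the compounds named here.

Measured in a functional assay on A-375 cells (Homo sapiens) for cytotoxicity, read by MTT assay, with a stated time of 72 h (a higher number here means a weaker inhibitor, a lower number a stronger inhibitor), so far:
- compound 1 `N/C(=N\NC(=S)N1CCOCC1)c1ccccn1`: 680 nM
- compound 2 `N/C(=N\NC(=S)N1CCSCC1)c1ccccn1`: 760 nM
- compound 3 `N/C(=N\NC(=S)N1CCSCC1)c1ccc(F)cn1`: 900 nM

Compound 2 stands second highest of the three numbers. Its nearest neighbour is compound 1 with a 1.1-fold higher number from compound 1 to compound 2 (0.05 log units; within the scatter), and the furthest is compound 3 with a 1.2-fold higher number from compound 2 to compound 3 (0.07 log units; within the scatter); both steps lie within the scatter, so the three compounds cannot be separated on these numbers.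

The next compound is compound 4 `N/C(=N\NC(=S)N1CCCC1)c1ccccn1`. It differs from compound 2 in one place: pyrrolidin-1-yl in place of thiomorpholin-4-yl on a thiocarbonyl carbon.

Going by the values given here, the only measured step at the same place is the one from compound 1 to compound 2, where one six-membered ring on the thiocarbonyl carbon was exchanged for another, and it gave a 1.1-fold higher number from compound 1 to compound 2 (0.05 log units; within the scatter), within the scatter. The step from compound 2 to compound 3 changes a different position and is also within the scatter. Among the compounds with values here, nothing measured so far shows a change beyond the scatter at any position of this core, so the step from compound 2 to compound 4 in this assay is expected to be a 1.1-fold higher number from compound 2 to compound 4 (0.02 log units; within the scatter), that is, no change beyond the scatter in either direction. On this basis compound 4 is estimated at 800 nM, with a range from 400 nM to 1600 nM.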

Compound 4, half-maximal inhibitory concentration: 600 nM
The estimate for compound 4 lay 1.3-fold (0.12 log units) above the measured number; the range from low to high includes it.
By their numbers in this assay, from the lowest: compounds 4, 1, 2 and 3 (each within the scatter of the next).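

In this assay, the thiocarbonyl carbon now carries a five-membered ring as well as the two six-membered rings, and the exchange reads the same from either of them: pyrrolidin-1-yl in place of thiomorpholin-4-yl gives (a 1.3-fold lower number from compound 2 to compound 4 (0.10 log units; within the scatter)), and pyrrolidin-1-yl in place of morpholin-4-yl gives (a 1.1-fold lower number from compound 1 to compound 4 (0.05 log units; within the scatter)). The earlier step only swapped one six-membered ring with 2 hetero atoms for another, whereas these steps change the ring size and leave a ring with 1 hetero atom, and the number still stays within the scatter for compounds 1, 2 and 4, with none of the three going against this. No independent data bear on why this position responds so little.

Still open, from the compounds shown here alone, is whether any group on the thiocarbonyl carbon moves the number beyond the scatter, for example an open-chain diethylamino group, a piperazin-1-yl ring with its free amine, or a pyrrolidine ring carrying a carboxylic acid. Also open, going by these compounds, is whether fluoro on the aromatic carbon reads the same with pyrrolidin-1-yl as with thiomorpholin-4-yl.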